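Extending the bromoalkoxy chain on the methoxyphenyl ring

The source may report more compounds than this note shows. Statements on the series, on what has been measured and on what is new or still open speak of the compounds shown alone.

Measured compounds:
compound 1 `COc1ccc(N(C)c2ccnc(Cl)n2)cc1`: 2820 nM
compound 2 `COc1ccc(N(C)c2ccnc(Cl)n2)cc1OCCBr`: 6620 nM

Both compounds share a core and were tested in a functional assay on MDA-MB-231 cells (Homo sapiens) for antiproliferative activity, read by MTT assay, with a stated time of 48 h; a higher number here means a weaker inhibitor, a lower number a stronger inhibitor. Compound 1 gives 2820 nM there, the lowest of the two numbers shown; compound 2 gives 6620 nM. Among the measured compounds shown here, the one step between them, a 2.3-fold higher number from compound 1 to compound 2 (0.37 log units; beyond the scatter), comes from placing a 2-bromoethoxy group in place of hydrogen on an aromatic carbon.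

Compound 3 `COc1ccc(N(C)c2ccnc(Cl)n2)cc1OCCCCCBr` is not yet measured. It differs from compound 1 in one place: (5-bromopentyl)oxy in place of hydrogen on an aromatic carbon. The entering group sits on the same aromatic carbon that carries the 2-bromoethoxy group in compound 2, but the chain is longer by three carbon atoms.

For the measured compounds named here, the only step that bears on this change is a 2.3-fold higher number from compound 1 to compound 2 (0.37 log units; beyond the scatter), a modest rise in the number. By analogy, compound 3 is expected to lie near or somewhat above compound 2, with a step of about a 2.3-fold higher number from compound 1 to compound 3 (0.36 log units; beyond the scatter). The estimate for compound 3 in this assay is therefore 6500 nM, with a range from 2500 nM to 16000 nM.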

Compound 3, half-maximal inhibitory concentration: > 10000 nM
Compound 3: only a limit was reported; the forecaster's own chance of this, stated with the estimate: 5%; at least 1.5-fold (0.18 log units) between middle value and limit.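

In this assay the result for compound 3 is a limit of the assay and not a number: the limit of > 10000 nM in this assay, at which 1 of the 3 values shown sits. A second bromoalkoxy chain on this aromatic carbon, ortho to a methoxy group, again gives a higher number than hydrogen, with an at least 3.5-fold higher number from compound 1 to compound 3 (0.54 log units; beyond the scatter), and compound 1 stays the lowest of the three compounds. Lengthening the chain itself gives an at least 1.5-fold higher number from compound 2 to compound 3 (0.17 log units; that floor lies within the scatter), so the limit alone does not separate the (5-bromopentyl)oxy group from the 2-bromoethoxy group, and no trend with chain length can be claimed from these compounds.

On these data alone, how far compound 3 lies past its limit stays open, and with it the true size of both steps. The compounds shown also cannot tell whether the rise follows the chain or its terminal bromine, a question that a chain of the same length ending in an amine or a hydroxyl group, or a plain alkoxy chain without bromine, would bear on directly.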